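A Benzyl Arm Trimmed to Phenyl

The source may hold more compounds than are shown below. What is called first, only, known or untested is meant among the compounds shown, and "the series" means these compounds.

Measured so far in a functional assay on the whole organism (strain Wistar albino) for inhibition, with Rattus norvegicus as the target, read by paw edema, with a stated time of 1 h, at a dose of 40 mg/kg by the oral route; on this read-out lower numbers stand for less inhibition and higher numbers for more inhibition at the one dose given (going by the name of the read-out):
compound 1 `Cc1nc(Cc2ccc(Cl)cc2)sc1C1SCC(=O)N1c1ccc(F)c(Cl)c1` gives 40.7%
compound 2 `COc1ccc(N2C(=O)CSC2c2sc(Cc3ccc(Cl)cc3)nc2C)cc1` gives 20.9%

Going by the values given here, compound 2 stands lowest of the two numbers in this assay; its nearest neighbour is compound 1, and the only step known, a number 19.8 percentage points lower from compound 1 to compound 2 (beyond the scatter), changes the group on the amide-type nitrogen in the ring, not the arm on the five-membered aromatic ring.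

Compound 3 `COc1ccc(N2C(=O)CSC2c2sc(-c3ccc(Cl)cc3)nc2C)cc1` has not been measured. It differs from compound 2 by 4-chlorophenyl in place of 4-chlorobenzyl on an aromatic carbon. No measured step touches this position, so nothing shown tells how the paw edema read-out responds to it. Among the compounds with values here, the only guide is the value of compound 2, 20.9%.

Within the data shown here, with no step to lean on, compound 3 is expected to sit near compound 2, a step of a number 1.1 percentage points higher from compound 2 to compound 3 (within the scatter) in this assay, not beyond the scatter. The estimate for compound 3 is 22%, within 8% to 38%.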

Compound 3, a percentage reported as inhibition, in the whole organism at one dose (the size of the read-out at that dose, not a potency): 54%
Estimate against measurement, compound 3: 32 percentage points below; the measured number lies above the stated range.
By their numbers in this assay, from the lowest: compound 2; then compound 1; then compound 3.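

Going by these compounds alone, the arm on the aromatic carbon of the five-membered ring, which no earlier step touched, proves to matter in this assay: a number 33.1 percentage points higher from compound 2 to compound 3 (beyond the scatter). The change is small on paper, since the chlorine-bearing six-membered ring stays and only the carbon linking it to the five-membered ring goes, yet this one pair shows that a small edit here can shift the read-out well beyond the scatter. Nothing shown gives a reason for a step of this size.

On these data alone, it remains open whether 4-chlorophenyl would bring a similar step with 3-chloro-4-fluorophenyl on the amide-type nitrogen in place of 4-methoxyphenyl. Also open, as far as these compounds go, is how the read-out would respond at this position to a longer chain or an amine between the two rings.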